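Changing the Group on the Ring Nitrogen: An Estimate

The source may report more compounds than this note shows. Statements on the series, on what has been measured and on what is new or still open speak of the compounds shown alone.

Measured so far:
- compound 1 `Nc1scc(CN2CCN(C3CCCCCC3)CC2)c1C(=O)c1ccc(Cl)cc1`: -25%
- compound 2 `Nc1scc(CN2CCN(c3cccc4ccccc34)CC2)c1C(=O)c1ccc(Cl)cc1`: -21%
- compound 3 `Nc1scc(CN2CCN(CCCc3ccc(Cl)cc3)CC2)c1C(=O)c1ccc(Cl)cc1`: not yet measured

In a functional assay on CHO cells with adenosine receptor A1 (Homo sapiens) as the target, read by cAMP accumulation and immunoassay, with a stated time of 6 min, tested at 10 uM (on this read-out higher numbers stand for a weaker effect at the one concentration tested and lower numbers for a stronger effect), compound 1 gives -25% and compound 2 gives -21%. Compound 2 shows the highest of the two numbers, but the step of a number 4 percentage points higher from compound 1 to compound 2 (within the scatter) means the two compounds cannot be told apart on this read-out.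

Compound 3 `Nc1scc(CN2CCN(CCCc3ccc(Cl)cc3)CC2)c1C(=O)c1ccc(Cl)cc1` differs from compound 2 in one place: 3-(4-chlorophenyl)propyl in place of naphthalen-1-yl on an amine nitrogen in a ring. Among the compounds with values here, the only measured step that bears on this is the one from compound 1 to compound 2, which also exchanged the group on this ring nitrogen, and it was a number 4 percentage points higher from compound 1 to compound 2 (within the scatter). With one step of that kind, and it within the scatter, the expectation for compound 3 is a step of a number 1 percentage points lower from compound 2 to compound 3 (within the scatter), that is nothing beyond the scatter. Compound 3 is therefore estimated at -22%, expected between -40% and -2%.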

Compound 3, a percentage reported as activity, at one concentration (the size of the read-out at that concentration, not a potency): -76%
Compound 3: the middle estimate sits 54 percentage points above what was measured; the measured number lies below the stated range.
By their numbers in this assay, from the lowest: compound 3; then compounds 1 and 2 (each within the scatter of the next).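

With 3-(4-chlorophenyl)propyl in place of naphthalen-1-yl on the ring nitrogen, this assay shows a number 55 percentage points lower from compound 2 to compound 3 (beyond the scatter), and with the same group in place of cycloheptyl it shows a number 51 percentage points lower from compound 1 to compound 3 (beyond the scatter), which in both cases means a stronger effect at the one concentration tested. This position looked indifferent while it held only cycloheptyl or naphthalen-1-yl, yet it can clearly move the read-out, even though the entering and leaving groups in the first change have the same number of heavy atoms. Nothing available explains why this group behaves so differently.

Compound 3 brings a carbon chain, a single aromatic ring and a chlorine together, so the compounds shown do not separate their contributions. A plain 3-phenylpropyl group or the shorter 2-(4-chlorophenyl)ethyl group would be the comparisons that begin to do so.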